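This account rests on a few compounds, and the source may have more. Where it says the series, first, only, none or still open, it means among the compounds named here.

In an ADME assay (liver) for metabolic stability, with Liver microsome (Rattus norvegicus) as the target, using microsomes (a higher number here means faster removal of the compound, a lower number slower removal), compound 1 (`CN(C(=O)c1cc(-c2ccccn2)[nH]n1)c1ccc(OCB2C=Cc3ccccc3N2)cc1`) gives 25 mL/min/kg. This lies within the scatter of compound 2 (`CN(C(=O)c1cc(-c2ccccn2)[nH]n1)c1ccc(OCc2ccc3ccccc3c2)cc1`) at 30 mL/min/kg, while compound 3 (`CN(C(=O)c1cc(-c2ccccc2)n[nH]1)c1ccc(OCc2ccc3ccccc3c2)cc1`) gives a lower 6.83 mL/min/kg. Compound 4 (`CN(C(=O)c1csc(-c2cccnc2)n1)c1ccc(OCB2C=Cc3ccccc3N2)cc1`) differs from compound 1 in one group on a carbonyl carbon: 2-(pyridin-3-yl)-1,3-thiazol-4-yl in place of 5-(pyridin-2-yl)-1H-pyrazol-3-yl on a carbonyl carbon. Among the compounds with values here, the only measured step at that place is a 4.4-fold lower number from compound 2 to compound 3 (0.64 log units; beyond the scatter), which is modest but beyond the scatter. It involves a different incoming group, so it is only a loose guide. The other step, a 1.2-fold higher number from compound 1 to compound 2 (0.08 log units; within the scatter), lies within the scatter and changes a different group. A small move towards lower numbers is therefore expected, probably not beyond the scatter, and the expected step is a 1.6-fold lower number from compound 1 to compound 4 (0.19 log units; within the scatter). Compound 4 is estimated at 16 mL/min/kg, with an expected range of 6 mL/min/kg to 40 mL/min/kg.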

Compound 4, clearance: > 283 mL/min/kg
Compound 4: a limit, no number; the forecaster's own chance of this, stated with the estimate: 3%; middle value at least 17-fold (1.24 log units) from the limit.
By their numbers in this assay, from the lowest: compound 3; then compounds 1 and 2 (each within the scatter of the next). At a limit, above all of these: compound 4.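

The group on the carbonyl carbon can move this read-out sharply upward: in this assay, 2-(pyridin-3-yl)-1,3-thiazol-4-yl in place of 5-(pyridin-2-yl)-1H-pyrazol-3-yl gives an at least 11-fold higher number from compound 1 to compound 4 (1.05 log units; beyond the scatter). The earlier step at this place, a 4.4-fold lower number from compound 2 to compound 3 (0.64 log units; beyond the scatter), ran the other way, so this place can shift the number in either direction, though these two steps have different groups at the other end of the molecule. The value of compound 4 is a limit and not a number: the limit of > 283 mL/min/kg in this assay, at which 1 of the 4 values shown sits.

The compounds shown leave open whether the thiazolyl ring or the pyridin-3-yl part carries the step. Also open, from the compounds shown here alone, is how an amine or a carboxylic acid on this group would read.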